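Series notes: amino in place of dimethylamino

The source may hold more compounds than are shown below. What is called first, only, known or untested is meant among the compounds shown, and "the series" means these compounds.

For the measured compounds named here, compound 2 `CN(C)c1ccc(C(=O)/C=C/C2=Cc3ccccc3OC2)cc1` gives 57.3% in a functional assay on the whole organism for inhibition, with Mus musculus as the target, with a stated time of 1 h, at a dose of 30 mg/kg by the intraperitoneal route; on this read-out lower numbers stand for less inhibition and higher numbers for more inhibition at the one dose given (going by the name of the read-out); it is one of two numbers so far, the other being compound 1 `O=C(/C=C/C1=Cc2ccccc2OC1)c1ccc(Br)cc1` with 66% in this assay, and the step of a number 8.7 percentage points lower from compound 1 to compound 2 (within the scatter) lies within the scatter. Compound 3 `Nc1ccc(C(=O)/C=C/C2=Cc3ccccc3OC2)cc1` differs from compound 2 as follows: amino in place of dimethylamino on an aromatic carbon. Going by the values given here, the only step at this place, from compound 1 to compound 2, did not move the read-out beyond the scatter, and no step for the amino exchange itself exists. The step of a number 2.3 percentage points lower from compound 2 to compound 3 (within the scatter) is therefore expected to stay within the scatter. Compound 3 is estimated at 55%, expected between 40% and 70%.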

Compound 3, a percentage reported as inhibition, in the whole organism at one dose (the size of the read-out at that dose, not a potency): 52.6%
Estimate against measurement, compound 3: 2.4 percentage points above; the measured number falls inside the stated range.
By their numbers in this assay, from the lowest: compounds 3, 2 and 1 (each within the scatter of the next, the first and the last beyond it).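

In this assay the exchange of dimethylamino for amino gives a number 4.7 percentage points lower from compound 2 to compound 3 (within the scatter), so the hydrogen-bond donor entering with amino goes with no step beyond the scatter. Set against bromo, amino gives a number 13.4 percentage points lower from compound 1 to compound 3 (beyond the scatter), the only step at this position that leaves the scatter, and it is modest. Nothing at hand accounts for either step.

Open, as far as these compounds go, is whether methoxy, a carboxylic acid or a longer amine chain at this position would read with bromo or with amino. Also open, from the compounds shown here alone, is whether the step away from bromo holds beyond these three compounds.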